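Swapping a fused ring for a methoxyphenoxy group

The source may report more compounds than this note shows. Statements on the series, on what has been measured and on what is new or still open speak of the compounds shown alone.

Measured so far:
compound 1 `Cc1ccc(-n2nc(C)c3c2NC(=O)[C@H](C)S[C@@H]3c2ccc(Oc3ccccc3)cc2)cc1` — 3400 nM
compound 2 `Cc1ccccc1-n1nc(C)c2c1NC(=O)[C@H](C)S[C@@H]2c1ccc(-c2cc3ccccc3o2)cc1` — 1500 nM
compound 3 `Cc1nn(-c2ccccc2F)c2c1C(c1ccc(Oc3ccccc3)cc1)SC(C)C(=O)N2` — 3900 nM

Of the compounds shown here, three built on the same core have been tested in an assay on isolated protein for agonist activity at Bile acid receptor (Homo sapiens), read by AlphaScreen, with a stated time of 30 min; a lower number here means that less compound is needed, a higher number that more compound is needed for the effect. Compound 2, which carries the 1-benzofuran-2-yl group, gives 1500 nM, the lowest of the three numbers. Compound 1 needs more, with 3400 nM, and compound 3 more still, with 3900 nM. Both gaps from compound 2 lie beyond the usual scatter, so compound 2 stands apart as the one needing the least.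

The next compound, compound 4 `COc1ccccc1Oc1ccc([C@H]2S[C@@H](C)C(=O)Nc3c2c(C)nn3-c2ccccc2C)cc1`, keeps the core of compound 2 and changes one group: 2-methoxyphenoxy in place of 1-benzofuran-2-yl on an aromatic carbon. Going by the values given here, nothing measured so far isolates this single change, so the expectation rests on the spread of the three numbers. Compound 1 and compound 3, which both carry a phenoxy-type group at that position, give higher numbers than compound 2, and compound 4 carries a related group. Compound 4 is therefore expected to need somewhat more than compound 2, with the step of a 2.0-fold higher number from compound 2 to compound 4 (0.30 log units; within the scatter) estimated to fall near or just beyond the scatter. The estimate for compound 4 in this assay is 3000 nM, within a range of 1200 nM to 8000 nM.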

Compound 4, half-maximal effective concentration: 1700 nM
Compound 4: middle estimate off by 1.8-fold (0.25 log units), on the high side; low and high end bracket the measured number.
By their numbers in this assay, from the lowest: compounds 2, 4, 1 and 3 (each within the scatter of the next, the first and the last beyond it).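

In this assay, placing 2-methoxyphenoxy where 1-benzofuran-2-yl stood, on an aromatic carbon para to a large group, gives a 1.1-fold higher number from compound 2 to compound 4 (0.05 log units; within the scatter) and so produces no readable difference. Going by these compounds alone, this is the first comparison that changes this position alone, and it shows that the position tolerates this exchange: a five-membered and a six-membered aromatic ring leave, a single six-membered aromatic ring enters with its methoxy and ether oxygens, hydrogen-bond acceptors go from 1 to 2, and the number stays within the scatter. No supporting measurement explains why these two different groups read alike.

The compounds shown leave open whether the methoxy group contributes anything, as no pair compares 2-methoxyphenoxy with plain phenoxy on an otherwise identical compound. They also leave open how this position would respond to a very different group, such as a carboxylic acid, an amine or a longer alkyl chain, since both groups compared here are built around aromatic rings.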